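Compound 4: restoring the sulfonyl arm lost in compound 3

The source may report more compounds than this note shows. Statements on the series, on what has been measured and on what is new or still open speak of the compounds shown alone.

Compound 1 `O=C1O[C@H]([C@@H](O)Cn2cc(CNS(=O)(=O)c3ccc(Cl)cc3)nn2)C(OCc2ccccc2)=C1OCc1ccccc1`: 7510 nM
Compound 2 `O=C1O[C@H]([C@@H](O)Cn2cc(CCCCl)nn2)C(OCc2ccccc2)=C1OCc1ccccc1`: 35000 nM
Compound 3 `O=C1O[C@H]([C@@H](O)Cn2cc(CCO)nn2)C(OCc2ccccc2)=C1OCc1ccccc1`: 68100 nM

In a functional assay on HepG2 cells (Homo sapiens) for antiproliferative activity, read by MTT assay, with a stated time of 72 h (on this read-out lower numbers stand for stronger inhibition and higher numbers for weaker inhibition), compound 3 gives 68100 nM, the highest of the three numbers. The relevant measured steps are a 9.1-fold higher number from compound 1 to compound 3 (0.96 log units; beyond the scatter) and a 1.9-fold higher number from compound 2 to compound 3 (0.29 log units; within the scatter). Compound 4 `O=C1O[C@H]([C@@H](O)Cn2cc(CNS(=O)(=O)c3ccc(Cl)cc3F)nn2)C(OCc2ccccc2)=C1OCc1ccccc1` differs from compound 3 by ((4-chloro-2-fluorophenyl)sulfonyl)amino in place of hydroxymethyl on a saturated chain carbon bound to an aromatic carbon. Among the compounds with values here, the entering group is the one present in compound 1, carrying one extra fluorine, so the change largely runs the step from compound 1 to compound 3 backwards. Because a 9.1-fold higher number from compound 1 to compound 3 (0.96 log units; beyond the scatter) was beyond the scatter, a step downward of similar size is expected, a 9.1-fold lower number from compound 3 to compound 4 (0.96 log units; beyond the scatter). Compound 4 is therefore estimated at 7500 nM, with a range from 3000 nM to 20000 nM.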

Compound 4, half-maximal inhibitory concentration: 25500 nM
Beside the measured number, compound 4's estimate is 3.4-fold (0.53 log units) below it; measured number outside the range, above it.
By their numbers in this assay, from the lowest: compound 1; then compounds 4, 2 and 3 (each within the scatter of the next, the first and the last beyond it).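

In this assay, a single fluoro in place of hydrogen on an aromatic carbon is enough to shift the result (a 3.4-fold higher number from compound 1 to compound 4 (0.53 log units; beyond the scatter)), so this arm does not tolerate every small change on its ring. The fluorinated arm still differs from hydroxymethyl (a 2.7-fold lower number from compound 3 to compound 4 (0.43 log units; beyond the scatter)), but not from 2-chloroethyl (a 1.4-fold lower number from compound 2 to compound 4 (0.14 log units; within the scatter)). No measured evidence accounts for this shift.

On these data alone, whether a bromo or methoxy group in place of that fluoro would behave the same remains open. So does whether an amide linker could replace the sulfonyl amino link.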